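Styryl pyranone series: aryl amine in place of cyclohexyl

The compounds below may be only part of what the source reports. "The series", "measured", "known", "first", "only" and "open" are said of these compounds alone.

Of the compounds shown here, two have numbers so far. Compound 1 `O=c1cc(NC2CCCCC2)cc(/C=C/c2ccccc2)o1` carries a cyclohexyl group on the ring nitrogen; in a functional assay on DU-145 cells (Homo sapiens) for cytotoxicity, read by MTT assay, with a stated time of 72 h (on this read-out lower numbers stand for an effect already at smaller amounts and higher numbers for an effect only at larger amounts of compound), compound 1 gives 1.23 uM, the higher of the two numbers. Compound 2 `COc1cccc(Nc2cc(-c3ccccc3)oc(=O)c2)c1`, which carries an aromatic amine substituent and a phenyl group on the core, gives in this assay 0.66 uM. The two values stand within the scatter of each other, so no order between compound 1 and compound 2 can be read from them.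

The next compound, compound 3 `COc1ccc(Nc2cc(/C=C/c3ccccc3)oc(=O)c2)cc1`, keeps the core and the styryl group of compound 1 and changes only the amine substituent: 4-methoxyphenyl in place of cyclohexyl on a nitrogen on an aromatic ring. Among the measured compounds shown here, no measured pair isolates this change, so the direction can be read only loosely from compound 2, whose value of 0.66 uM shows that an aromatic amine substituent is compatible with a number in the same range as compound 1. The step from compound 1 to compound 3 is therefore expected to be small, a 1.4-fold lower number from compound 1 to compound 3 (0.14 log units; within the scatter), not beyond the scatter in either direction. For compound 3 the expected value in this assay is 0.9 uM, within a range of 0.3 uM to 2.5 uM.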

Compound 3, concentration for half-maximal effect: 0.11 uM
Estimate against measurement, compound 3: 8.2-fold (0.91 log units) above; the whole stated range lies above it.
By their numbers in this assay, from the lowest: compound 3; then compounds 2 and 1 (each within the scatter of the next).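

In this assay, 4-methoxyphenyl in place of cyclohexyl on a nitrogen on an aromatic ring comes with an 11-fold lower number from compound 1 to compound 3 (1.05 log units; beyond the scatter), with the core and the styryl group unchanged. Among the compounds shown here, this is the first step read from a pair that differs in one place, and it lies beyond the scatter, so the group on this nitrogen clearly matters for the number in this assay, which the two earlier values could not show. No measurement at hand accounts for the size of this step.

From the compounds shown here alone, the exchange replaces a non-aromatic carbon ring with an aromatic one and adds a methoxy group in the same step, so the share of each in the step stays open. A plain phenyl on the nitrogen would separate the two, while a 4-hydroxyphenyl or a benzyl group would show how far the step depends on the oxygen substituent and on the aromatic ring sitting directly on the nitrogen.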